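This account rests on a few compounds, and the source may have more. Where it says the series, first, only, none or still open, it means among the compounds named here.

Measured so far in a functional assay (microsomes, liver) with Rattus norvegicus as the target; on this read-out higher numbers stand for weaker inhibition and lower numbers for stronger inhibition:
compound 1 `Cc1c(C)c2c(c(C)c1N)CC(C)(C)O2`: 760 nM
compound 2 `Cc1c(C)c2c(c(C)c1N)CC(C)(CSc1ccc(O)cc1)O2`: 220 nM

Of these two, compound 2 has the lower number and so the stronger inhibition, and the gap to compound 1 lies beyond the usual scatter. Compound 3 `Cc1c(C)c2c(c(C)c1N)CC(C)(CSc1ccncc1)O2` has not yet been measured. It carries pyridin-4-yl in place of 4-hydroxyphenyl on a sulfur. Among the measured compounds shown here, no measured pair of compounds differs in one place only, so nothing shows directly what such a swap does in this assay. The expectation is therefore a cautious one. Compound 2 sits at the low end at 220 nM, so a moderate rise towards weaker inhibition seems more likely than a further fall. The expected change is a 2.2-fold higher number from compound 2 to compound 3 (0.34 log units; beyond the scatter). For compound 3 the estimated value is 480 nM, with an expected range of 150 nM to 1400 nM.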

Compound 3, half-maximal inhibitory concentration: 630 nM
The estimate for compound 3 lay 1.3-fold (0.12 log units) below the measured number; low and high end bracket the measured number.
By their numbers in this assay, from the lowest: compound 2; then compounds 3 and 1 (each within the scatter of the next).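

In this assay, pyridin-4-yl in place of 4-hydroxyphenyl on the sulfur gives a 2.9-fold higher number from compound 2 to compound 3 (0.46 log units; beyond the scatter), so this position responds to which ring it carries, and a six-membered aromatic ring alone does not hold the number at the level of compound 2. Placing (pyridin-4-yl)sulfanyl instead of hydrogen on the saturated chain carbon gives a 1.2-fold lower number from compound 1 to compound 3 (0.08 log units; within the scatter), so this larger group leaves compound 3 indistinguishable from compound 1 in this read-out. Nothing available explains why the two rings differ.

On these data alone, it remains open whether the hydroxyl group or the ring nitrogen separates compound 2 from compound 3, and a plain phenyl ring on the same sulfur would help to settle that. As far as these compounds go, how a 4-aminophenyl or 4-carboxyphenyl group would read at this position is also open.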